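This account rests on a few compounds, and the source may have more. Where it says the series, first, only, none or still open, it means among the compounds named here.

Compound 1 `Nc1scc(CN2CCN(c3ccc(Cl)cc3Cl)CC2)c1C(=O)c1ccc(Cl)cc1` is the reference point. In a functional assay on CHO cells with adenosine receptor A1 (Homo sapiens) as the target, read by cAMP accumulation and immunoassay, with a stated time of 6 min, tested at 10 uM (on this read-out higher numbers stand for a weaker effect at the one concentration tested and lower numbers for a stronger effect), compound 1 gives -74%. Compound 2 `Nc1scc(CN2CCN(c3cc(Cl)cc(Cl)c3)CC2)c1C(=O)c1ccc(Cl)cc1` gives -74% in this assay, and compound 3 `Nc1scc(CN2CCN(c3cccnc3)CC2)c1C(=O)c1ccc(Cl)cc1` gives -23%. Compound 1 thus stands level with compound 2, the two together at the lowest of the three numbers, while compound 3 lies well apart. The steps show it: no change at the digits printed from compound 1 to compound 2 (within the scatter), whereas a number 51 percentage points higher from compound 1 to compound 3 (beyond the scatter) and a number 51 percentage points higher from compound 2 to compound 3 (beyond the scatter).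

Compound 4 `Nc1scc(CN2CCN(c3cccc4ccccc34)CC2)c1C(=O)c1ccc(Cl)cc1` is not yet measured. It differs from compound 1 in one place: naphthalen-1-yl in place of 2,4-dichlorophenyl on an amine nitrogen in a ring. For the measured compounds named here, two measured steps bear on this. The swap of one dichlorophenyl for another left the number unchanged, and the swap for pyridin-3-yl moved it far toward the weaker end. Naphthalen-1-yl, like the dichlorophenyls, is built of carbon only and carries no hydrogen-bond acceptors, so the closer precedent is the first step. The estimated outcome for compound 4 is therefore a number 6 percentage points higher from compound 1 to compound 4 (within the scatter), a step within the scatter. Compound 4 is expected to give about -68%, between -90% and -38%.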

Compound 4, a percentage reported as activity, at one concentration (the size of the read-out at that concentration, not a potency): -21%
Compound 4: middle estimate off by 47 percentage points, on the low side, and the stated range ends below it.
By their numbers in this assay, from the lowest: compounds 1 and 2 (each within the scatter of the next); then compounds 3 and 4 (each within the scatter of the next).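

In this assay, naphthalen-1-yl in place of either dichlorophenyl gives a number 53 percentage points higher from compound 1 to compound 4 (beyond the scatter) and also a number 53 percentage points higher from compound 2 to compound 4 (beyond the scatter) so an aromatic group of carbon only on this amine nitrogen does not by itself keep the stronger effect of compound 1 and compound 2. Naphthalen-1-yl in place of pyridin-3-yl gives a number 2 percentage points higher from compound 3 to compound 4 (within the scatter) so the two groups end level here, and the large shift seen with pyridin-3-yl cannot be tied to its ring nitrogen alone. Nothing available here accounts for why the two dichlorophenyl compounds stand apart from the other two.

The compounds shown leave open whether the shift with naphthalen-1-yl goes with its second ring or with the loss of chlorine. An unsubstituted phenyl, a 4-chlorophenyl or a naphthalen-2-yl group on the same nitrogen would help separate these two readings.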